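A few compounds are considered here, and "the series" means these few. Any claim that something is new, unique, unknown or untested is made for them only; others in the source may bear on it.

Measured in a functional assay on HepG2 cells (Homo sapiens) for cytotoxicity, read by sulforhodamine B assay, with a stated time of 48 h; a lower number here means a stronger inhibitor, a higher number a weaker inhibitor:

compound 1 `C/C(=N\NC(=O)/C(C#N)=C/N(C)C)c1ccc(NS(=O)(=O)c2ccc(Cl)cc2)cc1`: 19400 nM
compound 2 `CCO/C=C(\C#N)C(=O)N/N=C(\C)c1ccc(NS(=O)(=O)c2ccc(Cl)cc2)cc1`: 16800 nM
compound 3 `CCOC(=O)c1c(-c2ccco2)c(C#N)c(=O)n(/N=C(\C)c2ccc(NS(=O)(=O)c3ccc(Cl)cc3)cc2)c1N`: 10300 nM

Compound 3 gives the lowest of the three numbers in this assay, but its gaps to compound 2 and to compound 1 are both within the scatter, so no order among the three can be read from them. Within the data shown here, the only single-site step measured so far, a 1.2-fold lower number from compound 1 to compound 2 (0.06 log units; within the scatter), concerns the chain that bears the nitrile in compounds 1 and 2 and lies within the scatter.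

Compound 4 `CCOC(=O)c1c(-c2ccc(OC)cc2)c(C#N)c(=O)n(/N=C(\C)c2ccc(NS(=O)(=O)c3ccc(Cl)cc3)cc2)c1N` is obtained from compound 3 by the change (4-methoxyphenyl in place of furan-2-yl on an aromatic carbon). Among the measured compounds shown here, no measured pair changes a substituent on the core of compound 3, so the step from compound 1 to compound 2 does not bear on this change, and the data give no precedent for it. For the measured compounds named here, with only the value of compound 3 as anchor and no step of any size beyond the scatter anywhere in the set, no shift beyond the scatter is expected, a 1.0-fold lower number from compound 3 to compound 4 (0.01 log units; within the scatter).

For compound 4 in this assay the expected value is 10000 nM, with a range from 4000 nM to 25000 nM.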

Compound 4, half-maximal inhibitory concentration: 61700 nM
The estimate for compound 4 lay 6.2-fold (0.79 log units) below the measured number; measured number outside the range, above it.
By their numbers in this assay, from the lowest: compounds 3, 2 and 1 (each within the scatter of the next); then compound 4.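

In this assay, among these compounds, 4-methoxyphenyl in place of furan-2-yl gives a 6.0-fold higher number from compound 3 to compound 4 (0.78 log units; beyond the scatter), the first step beyond the scatter. The aromatic carbon opposite the ring nitrogen of the shared core is therefore a place where a change of substituent moves this read-out, which the chain step, a 1.2-fold lower number from compound 1 to compound 2 (0.06 log units; within the scatter), could not show. The change replaces a five-membered aromatic ring with 1 hetero atom by a six-membered aromatic ring of carbon only and also adds heavy atoms, and no available measurement separates these features or accounts for the step.

From the compounds shown here alone, whether the ring or the methoxy group carries the step remains open; a plain phenyl or a thiophen-2-yl here would separate the two. Going by these compounds, how an amine or a carboxylic acid on that ring would read in this assay also remains open.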